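Ring amide nitrogen substituent and activity across the fused series

The compounds below may be only part of what the source reports. "The series", "measured", "known", "first", "only" and "open" are said of these compounds alone.

Measured compounds:
compound 1 `CC(C)[C@@H]1CC[C@@H](C)C[C@@]12N(C)C(=O)[C@@H]1[C@H]3C(=O)N(C)C(=O)[C@H]3ON12` gives 41.5% in a functional assay, read by spectrophotometry, with a stated time of 2 h, tested at 1 mg/mL; a higher number here means a stronger effect of the compound at the concentration tested, a lower number a weaker effect
compound 2 `CC(C)[C@@H]1CC[C@@H](C)C[C@@]12N(C)C(=O)[C@@H]1[C@H]3C(=O)N(c4ccccc4)C(=O)[C@H]3ON12` gives 29.7%
compound 3 `COc1ccc(N2C(=O)[C@H]3[C@H](ON4[C@@H]3C(=O)N(C)[C@@]43C[C@H](C)CC[C@H]3C(C)C)C2=O)cc1` gives 61%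

Compound 3 stands highest of the three numbers; the steps of a number 19.5 percentage points higher from compound 1 to compound 3 (beyond the scatter) and a number 31.3 percentage points higher from compound 2 to compound 3 (beyond the scatter) are both beyond the scatter, so its lead is real on these data. Compound 4 `Cc1ccc(N2C(=O)[C@H]3[C@H](ON4[C@@H]3C(=O)N(C)[C@@]43C[C@H](C)CC[C@H]3C(C)C)C2=O)c(C)c1` is the next variation: 2,4-dimethylphenyl in place of 4-methoxyphenyl on an amide-type nitrogen in a ring. The step that bears most directly is a number 31.3 percentage points higher from compound 2 to compound 3 (beyond the scatter), since compound 4 again lacks the methoxy; the step of a number 11.8 percentage points lower from compound 1 to compound 2 (beyond the scatter) shows the unsubstituted phenyl below methyl. Among the compounds with values here, no measured step covers methyl on the aromatic ring. A drop from compound 3 is therefore expected, probably landing between the values of compound 2 and compound 3, as a number 21 percentage points lower from compound 3 to compound 4 (beyond the scatter). For compound 4 the estimate is 40%, within 25% to 56%.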

Compound 4, a percentage reported as activity, at one concentration (the size of the read-out at that concentration, not a potency): 69%
Compound 4: the middle estimate sits 29 percentage points below what was measured; the whole stated range lies below it.
By their numbers in this assay, from the lowest: compound 2; then compound 1; then compounds 3 and 4 (each within the scatter of the next).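

On the amide-type nitrogen, 2,4-dimethylphenyl in place of 4-methoxyphenyl gives [ a number 8 percentage points higher from compound 3 to compound 4 (within the scatter) ], so a hydrogen-bond acceptor in this substituent is not required to reach the level of compound 3. The same group in place of phenyl gives [ a number 39.3 percentage points higher from compound 2 to compound 4 (beyond the scatter) ] and in place of methyl gives [ a number 27.5 percentage points higher from compound 1 to compound 4 (beyond the scatter) ], so a second substituted aryl group, not only the methoxy one, stands clear of both. No available data give a reason for these differences. On these data alone, whether a single methyl on the aromatic ring is enough remains open, as does the effect of an amine or a carboxylic acid on that ring.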